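Cytotoxicity Limits for Three Compounds and a Fourth

The source may report more compounds than this note shows. Statements on the series, on what has been measured and on what is new or still open speak of the compounds shown alone.

Compound 1 `O=c1nc(N2CCN(NC3CCCCC3)CC2)sc2c([N+](=O)[O-])cc(C(F)(F)F)cc12` in an ADME assay on Vero cells (Chlorocebus sabaeus) for cytotoxicity, read by MTT assay, with a stated time of 72 h; on this read-out higher numbers stand for lower toxicity in this test and lower numbers for higher toxicity in this test: compound 1 gives > 64 ug/mL, a limit of the assay.
Compound 2 `O=c1nc(N2CCN(NCc3cccc(C(F)(F)F)c3)CC2)sc2c([N+](=O)[O-])cc(C(F)(F)F)cc12`: compound 2 gives > 64 ug/mL, again a limit.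
Compound 3 `O=c1nc(N2CCN(NCc3ccc(Cl)cc3)CC2)sc2c([N+](=O)[O-])cc(C(F)(F)F)cc12`: compound 3 gives > 64 ug/mL, also a limit.

Compound 3 thus stands where all three measured compounds stand, at the limit of > 64 ug/mL in this assay, at which 3 of the 3 values shown sit, and no number places it above or below its neighbours. Because every value sits at the limit of > 64 ug/mL in this assay, at which 3 of the 3 values shown sit, the steps a step that the two limits leave unreadable from compound 1 to compound 2, a step that the two limits leave unreadable from compound 1 to compound 3 and a step that the two limits leave unreadable from compound 2 to compound 3 remain unreadable in size and direction. Compound 4 `COc1ccc(CNN2CCN(c3nc(=O)c4cc(C(F)(F)F)cc([N+](=O)[O-])c4s3)CC2)cc1` differs from compound 3 by methoxy in place of chloro on an aromatic carbon. With no readable step to draw on, compound 4 is expected to sit at the same limit, a step that the limit leaves unreadable from compound 3 to compound 4 that is expected to stay within the scatter. Compound 4 is therefore estimated at 80 ug/mL, between 40 ug/mL and 200 ug/mL.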

Compound 4, half-maximal cytotoxic concentration: > 64 ug/mL
Compound 4 gave a limit, no number; the forecaster's own chance of this, stated with the estimate: 85%; the middle value does not contradict the limit.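

No step to compound 4 from compound 1, compound 2 or compound 3 can be read, as all four compounds sit at one limit: the limit of > 64 ug/mL in this assay, at which 4 of the 4 values shown sit.

The compounds shown leave open whether any of these differences changes the result in this assay.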